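This account rests on a few compounds, and the source may have more. Where it says the series, first, only, none or still open, it means among the compounds named here.

Measured so far:
compound 1, `O=C(CCCc1cn(S(=O)(=O)c2cccs2)c2ccccc12)NCCCn1ccnc1`, with 5500 nM; 5010 nM (2 entries) in an assay on isolated protein for activation of Insulin-degrading enzyme (Homo sapiens), read by fluorescence, with stated times of 10 min and 20 min; a higher number here means that more compound is needed for the effect, a lower number that less compound is needed;
compound 2, `O=C(CCCc1c[nH]c2ccccc12)NCCCn1ccnc1`, with 10000 nM; 89100 nM (2 entries) in this assay;
compound 3, `O=C(CCCc1cn(C(=O)c2cccs2)c2ccccc12)NCCCn1ccnc1`, with 21400 nM in this assay.

Among these three, compound 3 shows the highest single number, so more of it is needed than of compound 1; compound 3 has also been run further times that gave no number. The repeated entries of compound 1 (the several entries of compound 1 in this assay, 5500 nM; 5010 nM (2 entries)) sit close together, whereas those of compound 2 (the several entries of compound 2 in this assay, 10000 nM; 89100 nM (2 entries)) are spread widely apart.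

Compound 4, `CS(=O)(=O)n1cc(CCCC(=O)NCCCn2ccnc2)c2ccccc21`, has not yet been measured. It differs from compound 3 in one place: methylsulfonyl in place of (thiophen-2-yl)carbonyl on an aromatic nitrogen. The change removes the aromatic ring of that group and keeps a small sulfur-bearing group on the aromatic nitrogen, which brings compound 4 closer in kind to compound 1 than to compound 3.

From this, compound 4 is expected to need a little less than compound 3, a modest step of a 2.1-fold lower number from compound 3 to compound 4 (0.33 log units; beyond the scatter), with an estimated 10000 nM and a plausible range from 3000 nM to 40000 nM.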

Compound 4, half-maximal effective concentration: 26900 nM
For compound 4 the middle estimate is 2.7-fold (0.43 log units) below the measured one; the range from low to high includes it.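

In this assay, putting methylsulfonyl in place of (thiophen-2-yl)carbonyl on the aromatic nitrogen gives a 1.3-fold higher number from compound 3 to compound 4 (0.10 log units; within the scatter), so these two groups cannot be told apart here, although one carries a five-membered aromatic ring and the other has no ring. A sulfonyl link alone therefore does not bring the lower number: compound 4 reads 26900 nM, while compound 1, which carries a thiophene ring on the same kind of link, reads 5500 nM; 5010 nM (2 entries). That gap rests on repeats that agree closely: the several entries of compound 1 in this assay, 5500 nM; 5010 nM (2 entries).

Going by these compounds, whether the lower number needs thiophene in particular stays open, and a phenylsulfonyl or ethylsulfonyl group at this nitrogen would address that. How these groups compare with the free aromatic nitrogen of compound 2 also stays unclear, since its repeats disagree: the several entries of compound 2 in this assay, 10000 nM; 89100 nM (2 entries)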